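Amide aryl variation on the shared core: compound 3

This account rests on a few compounds, and the source may have more. Where it says the series, first, only, none or still open, it means among the compounds named here.

Measured so far:
compound 1 `O=C(Nc1cccc(-c2oc3cc(-c4ccc(F)cc4)ccc3c(=O)c2O)c1)c1ccccc1F`: 7240 nM
compound 2 `Cc1ccccc1C(=O)Nc1cccc(-c2oc3cc(-c4ccc(F)cc4)ccc3c(=O)c2O)c1`: 4910 nM
compound 3 `CCc1ccc(C(=O)Nc2cccc(-c3oc4cc(-c5ccc(F)cc5)ccc4c(=O)c3O)c2)cc1`: not yet measured

In a functional assay on MDA-MB-231 cells (Homo sapiens) for antiproliferative activity, read by CCK-8 assay, with a stated time of 72 h (on this read-out higher numbers stand for weaker inhibition and lower numbers for stronger inhibition), compound 1 gives 7240 nM, the highest of the two numbers recorded; in this assay compound 2 gives 4910 nM. Among the compounds with values here, the only step recorded, a 1.5-fold lower number from compound 1 to compound 2 (0.17 log units; within the scatter), sits within the scatter, so the two values are not distinguishable.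

Compound 3 carries the change (4-ethylphenyl in place of 2-fluorophenyl on a carbonyl carbon). The measured step bears on it only loosely: it alters the same aryl group on the carbonyl carbon, but swaps a single substituent, whereas here the whole 2-fluorophenyl gives way to 4-ethylphenyl. Within the data shown here, with no direct precedent for a 4-ethylphenyl at this place and the one recorded step within the scatter, no shift beyond the scatter is expected in either direction, and the estimated step is a 1.2-fold lower number from compound 1 to compound 3 (0.08 log units; within the scatter), with a wide range to cover the lack of a comparable change. In this assay compound 3 is expected to give 6000 nM, estimated between 2500 nM and 15000 nM.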

Compound 3, half-maximal inhibitory concentration: 9070 nM
For compound 3 the middle estimate is 1.5-fold (0.18 log units) below the measured one; low and high end bracket the measured number.
By their numbers in this assay, from the lowest: compounds 2, 1 and 3 (each within the scatter of the next).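

In this assay the exchange of 2-fluorophenyl for 4-ethylphenyl on the carbonyl carbon gives a 1.3-fold higher number from compound 1 to compound 3 (0.10 log units; within the scatter) and the exchange of 2-methylphenyl for 4-ethylphenyl at the same place gives a 1.8-fold higher number from compound 2 to compound 3 (0.27 log units; within the scatter) and all three amides therefore remain inside the scatter of one another. Compared with the earlier single-substituent swap, this position has now also taken a change of the whole aryl group, including a different substituent and substitution pattern on the ring, without a readable shift in this cell read-out. No accompanying measurement bears on this result.

The three aryl amides leave open whether any change at this position can move the number beyond the scatter, for example a carboxylic acid or a dimethylamino group on the ring, a longer chain such as butyl, or a pyridine ring or cyclohexyl group in place of the phenyl ring. They also leave open whether 2-substituted and 4-substituted rings differ when they carry the same group, such as 2-ethylphenyl set against 4-ethylphenyl.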